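The source may report more compounds than this note shows. Statements on the series, on what has been measured and on what is new or still open speak of the compounds shown alone.

Three compounds of the series have numbers in an in vitro functional assay on cells for agonist activity at Bombesin receptor subtype-3 (Mus musculus), read by luminescence and calcium flux; a lower number here means that less compound is needed, a higher number that more compound is needed for the effect. Compound 1 `O=C(O)c1ccccc1-c1ccc(CCc2ncc(CC3CCCC3)[nH]2)cc1` gives 7.9 nM in this assay. Compound 2 `COc1ccc(Cc2cnc(CCc3ccc(-c4ccccc4C(=O)O)cc3)[nH]2)cc1` gives 513 nM, and compound 3 `CCCCc1cnc(CCc2ccc(-c3ccccc3C(=O)O)cc2)[nH]1` gives 93 nM. Compound 3 thus sits second highest of the three, closest to compound 2 and furthest from compound 1: the step of a 12-fold higher number from compound 1 to compound 3 (1.07 log units; beyond the scatter) is large, while the step of a 5.5-fold lower number from compound 2 to compound 3 (0.74 log units; beyond the scatter) is modest.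

Compound 4 `O=C(O)c1ccccc1-c1ccc(CCc2ncc(Cc3ccccc3)[nH]2)cc1` is not yet measured in this assay. It differs from compound 3 in one place: phenyl in place of propyl on a saturated chain carbon bound to an aromatic carbon. Within the data shown here, the closest precedent is the step of a 5.5-fold lower number from compound 2 to compound 3 (0.74 log units; beyond the scatter), in which 4-methoxyphenyl gave way to propyl on a saturated chain carbon bound to an aromatic carbon and the number fell; the reverse direction, an aromatic ring in place of a chain, points toward a higher number. The step of a 65-fold higher number from compound 1 to compound 2 (1.81 log units; beyond the scatter) shows 4-methoxyphenyl far above cyclopentyl in the same place, and a 12-fold higher number from compound 1 to compound 3 (1.07 log units; beyond the scatter) shows propyl also above cyclopentyl. Phenyl carries no methoxy; the precedent from compound 2 is only partial, and the expected rise is smaller than that step. The expected step of a 2.7-fold higher number from compound 3 to compound 4 (0.43 log units; beyond the scatter) points upward, beyond the scatter but modest. Compound 4 is estimated at 250 nM, with a range from 80 nM to 800 nM.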

Compound 4, half-maximal effective concentration: 11 nM
Compound 4: middle estimate off by 23-fold (1.36 log units), on the high side, outside the stated range (below it).
By their numbers in this assay, from the lowest: compounds 1 and 4 (each within the scatter of the next); then compound 3; then compound 2.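

In this assay, an aromatic ring on this saturated chain carbon does not by itself raise the number: phenyl in place of propyl goes the other way (an 8.5-fold lower number from compound 3 to compound 4 (0.93 log units; beyond the scatter)), and phenyl and cyclopentyl cannot be told apart (a 1.4-fold higher number from compound 1 to compound 4 (0.14 log units; within the scatter)). The high number of compound 2 therefore goes with the methoxy on the aromatic ring rather than with the ring, as hydrogen in place of methoxy on that aromatic carbon is a large step (a 47-fold lower number from compound 2 to compound 4 (1.67 log units; beyond the scatter)), and compound 2 stands against any reading that a ring at this position is enough for a low number, which holds only for compound 1 and compound 4. Nothing given here explains why these steps fall as they do.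

Still open, as far as these compounds go, is whether the rise belongs to methoxy alone or would also come with a hydroxyl, a fluorine or an amine on the phenyl ring. Also open, from the compounds shown here alone, is whether a cyclohexyl ring or a longer chain on the same saturated chain carbon would stay with compound 1 and compound 4 or move toward compound 3.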